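This account rests on a few compounds, and the source may have more. Where it says the series, first, only, none or still open, it means among the compounds named here.

Working notes on the series. The three measured compounds share one core and differ only in the group carried on the sulfur. Compound 1 `Cc1cc(N2CC[C@@H](C)[C@@H](N(C)c3ncnc4[nH]ccc34)C2)n2nc(SCC3CC3)nc2n1` carries cyclopropyl on the saturated chain carbon bound to the sulfur and in a functional assay on MGC-803 cells (Homo sapiens) for inhibition, read by MTT assay, with a stated time of 72 h (on this read-out higher numbers stand for weaker inhibition and lower numbers for stronger inhibition), compound 1 gives 9540 nM. Compound 2 `Cc1cc(N2CC[C@@H](C)[C@@H](N(C)c3ncnc4[nH]ccc34)C2)n2nc(SCc3nc4ccccc4[nH]3)nc2n1` carries 1H-benzimidazol-2-yl there and in this assay compound 2 gives 21200 nM. Compound 3 `Cc1cc(N2CC[C@@H](C)[C@@H](N(C)c3ncnc4[nH]ccc34)C2)n2nc(SCc3ccc([N+](=O)[O-])cc3)nc2n1` carries 4-nitrophenyl there and in this assay compound 3 gives 27000 nM.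

Among these three, compound 2 holds the second highest number: the gap to compound 3 is a 1.3-fold higher number from compound 2 to compound 3 (0.11 log units; within the scatter), while the other neighbouring step is a 2.2-fold higher number from compound 1 to compound 2 (0.35 log units; beyond the scatter). The parallel step a 2.8-fold higher number from compound 1 to compound 3 (0.45 log units; beyond the scatter) points the same way, so both aromatic replacements of cyclopropyl gave modest higher numbers.

Compound 4 `C#CSc1nc2nc(C)cc(N3CC[C@@H](C)[C@@H](N(C)c4ncnc5[nH]ccc45)C3)n2n1` is not yet measured. Relative to compound 2 the change is ethynyl in place of (1H-benzimidazol-2-yl)methyl on a sulfur. For the measured compounds named here, no measured step removes the chain carbon or puts a group straight on the sulfur, so the measured steps bear on it only indirectly: the smallest group measured, in compound 1, gave the lowest number. On that basis a modest lower number is expected for compound 4, of roughly a 1.9-fold lower number from compound 2 to compound 4 (0.28 log units; within the scatter). The estimate for compound 4 in this assay is 11000 nM, with a range from 3500 nM to 35000 nM.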

Compound 4, half-maximal inhibitory concentration: 18100 nM
Compound 4: the middle estimate sits 1.6-fold (0.22 log units) below what was measured, within the range that was stated.
By their numbers in this assay, from the lowest: compounds 1, 4, 2 and 3 (each within the scatter of the next, the first and the last beyond it).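

Working notes, continued. In this assay the swap on the sulfur removes both aromatic rings, the hydrogen-bond donor and the hydrogen-bond acceptor of (1H-benzimidazol-2-yl)methyl and brings in ethynyl, yet a 1.2-fold lower number from compound 2 to compound 4 (0.07 log units; within the scatter) stays within the scatter, so at this position that loss leaves no readable change in the number. The other two new steps, a 1.5-fold lower number from compound 3 to compound 4 (0.17 log units; within the scatter) and a 1.9-fold higher number from compound 1 to compound 4 (0.28 log units; within the scatter), are also within the scatter, so compound 4 cannot be separated from any of the three earlier compounds, even though the two ends of the series remain apart at a 2.8-fold higher number from compound 1 to compound 3 (0.45 log units; beyond the scatter). Nothing measured on these groups bears on this result, and no explanation can be offered for it.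

Compound 4 lacks the chain carbon and also differs in the group it carries, so the contribution of each of the two remains unresolved. Also open, going by these compounds, is whether a primary amine, a carboxylic acid or a longer alkyl chain on the sulfur would move the number beyond the scatter of these four compounds.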